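Ethylamino in Place of Methyl: Expected Cytotoxicity of Compound 4

The compounds below may be only part of what the source reports. "The series", "measured", "known", "first", "only" and "open" are said of these compounds alone.

Compound 1, `Cc1cc(C)n(-c2nc(-c3ccc(F)cc3)cc(=O)[nH]2)n1`: 4000 nM
Compound 2, `Cc1cc(C)n(-c2nc(-c3ccncc3)cc(=O)[nH]2)n1`: > 50000 nM (a limit of the assay)
Compound 3, `Cc1cc(C)n(-c2nc(-c3cccnc3)cc(=O)[nH]2)n1`: > 50000 nM (a limit of the assay)

In an ADME assay on CHO cells (Cricetulus griseus) for cytotoxicity, read by MTT assay (a higher number here means a weaker inhibitor, a lower number a stronger inhibitor), compound 1 gives 4000 nM. For compound 2 the reported value > 50000 nM is a limit of the assay and not a number. For compound 3 the value > 50000 nM is likewise a limit and not a number, so compound 3 stands at the limit of > 50000 nM in this assay, at which 2 of the 3 values shown sit. The step of an at least 12-fold higher number from compound 1 to compound 3 (1.09 log units; beyond the scatter) is large, and the step that the two limits leave unreadable from compound 2 to compound 3 cannot be read from two limits.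

Compound 4, `CCNc1cc(C)nn1-c1nc(-c2cccnc2)cc(=O)[nH]1`, differs from compound 3 in one place: ethylamino in place of methyl on an aromatic carbon. Among the measured compounds shown here, none of the measured steps changes this group; all of them exchange the aryl group on the shared core, so no measured step bears directly on the change from compound 3 to compound 4. Since compound 3 already sits at a limit, compound 4 is expected to stay there as well, and the step of a number no higher from compound 3 to compound 4 (the limit leaves the size open) is estimated to lie within the scatter. For compound 4 the estimated value in this assay is 50000 nM, with a range from 15000 nM to 150000 nM.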

Compound 4, half-maximal inhibitory concentration: > 50000 nM
Compound 4 ended at the assay's limit (the forecaster's own chance of this, stated with the estimate: 70%); the middle value sits exactly at the limit.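

In this assay compound 4 gives > 50000 nM, a limit of the assay and not a number. Compound 3 also stands at a limit, so no new step can be read between compound 3 and compound 4. The compounds shown leave open whether ethylamino in place of methyl shifts the value in this assay at all, and in which direction.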